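A few compounds are considered here, and "the series" means these few. Any claim that something is new, unique, unknown or untested is made for them only; others in the source may bear on it.

Three compounds that share a core and differ only in the group on a carbonyl carbon have been tested in a physicochemical assay for solubility, read by HPLC, using the shake flask method, in phosphate buffer, measured as kinetic solubility, with a stated time of 20 h, at pH 6.5; on this read-out higher numbers stand for higher solubility and lower numbers for lower solubility. Compound 1 `O=C(c1ccnc(Nc2nc3cnc(Nc4ccc(F)c(C(F)(F)F)c4)cc3[nH]2)c1)N1CCN(C2CC2)CC1` gives < 5000 nM, which is a limit and not a number. Compound 3 `C[C@@H]1CN(C(=O)c2ccnc(Nc3nc4cnc(Nc5ccc(F)c(C(F)(F)F)c5)cc4[nH]3)c2)C[C@H](C)O1` gives < 5000 nM, which is also a limit. Within the data shown here, compound 2 `C[C@@H]1CN(C(=O)c2ccnc(Nc3nc4cnc(Nc5ccc(F)c(C(F)(F)F)c5)cc4[nH]3)c2)C[C@H](C)N1` gives 200000 nM, the only true number of the three.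

The steps that can be read are an at least 40-fold higher number from compound 1 to compound 2 (1.60 log units; beyond the scatter) and an at least 40-fold lower number from compound 2 to compound 3 (1.60 log units; beyond the scatter), both large. Each of them starts or ends at the limit of < 5000 nM in this assay, at which 2 of the 3 values shown sit. Between the other two compounds there is only a step that the two limits leave unreadable from compound 1 to compound 3.

Compound 4 `C[C@@H]1CN(C(=O)c2ccnc(Nc3nc4cnc(Nc5cccc(C(F)(F)F)c5)cc4[nH]3)c2)C[C@H](C)N1` is compound 2 with a single change: hydrogen in place of fluoro on an aromatic carbon. This puts hydrogen in place of fluoro on an aromatic carbon, ortho to a trifluoromethyl group. Among the measured compounds shown here, none of the measured steps touches that place, so they give no direct measure of this change. All of them swap the group on the carbonyl carbon, and compound 4 keeps the 3,5-dimethylpiperazin-1-yl group of compound 2. The best guide is therefore compound 2 at 200000 nM, and no step beyond the scatter is expected in this assay. The expected change is no change at the digits printed from compound 2 to compound 4 (within the scatter). For compound 4 the estimate is 200000 nM, with an expected range of 80000 nM to 400000 nM.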

Compound 4, solubility: 200000 nM
The estimate for compound 4 equals the measured number at the digits printed, within the range that was stated.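

At the aromatic carbon ortho to a trifluoromethyl group, hydrogen in place of fluoro gives no change at the digits printed from compound 2 to compound 4 (within the scatter) in this assay. Among these compounds, this is the only measured change at this end of the molecule, since every earlier step swapped the group on the carbonyl carbon, and it shows that the 3-(trifluoromethyl)phenyl compound keeps the high number seen with 4-fluoro-3-(trifluoromethyl)phenyl. It is also the only step shown that joins two true numbers, whereas each earlier step touches a limit or is bounded by two of them, so its size can be read directly and not just as a bound: the limit of < 5000 nM in this assay, at which 2 of the 4 values shown sit.

A single swap of one atom says nothing yet about larger or different groups at this carbon, such as chloro, methoxy or a nitrile, or about replacing the trifluoromethyl group itself with a methyl group. As far as these compounds go, it also remains open whether hydrogen in place of fluoro would leave the number just as it is with the 2,6-dimethylmorpholin-4-yl or 4-cyclopropylpiperazin-1-yl group on the carbonyl carbon.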